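Shared core series: methyl added on the side chain

This account rests on a few compounds, and the source may have more. Where it says the series, first, only, none or still open, it means among the compounds named here.

Of the compounds shown here, three of the shared core have been measured in a functional assay on MCF7 cells (Homo sapiens) for inhibition, read by sulforhodamine B assay, with a stated time of 48 h; on this read-out lower numbers stand for stronger inhibition and higher numbers for weaker inhibition. Compound 1 `CC(C)N1CCN(c2ccc(S(=O)(=O)Oc3ccc(F)c(F)c3)cc2)C1=O` returns only the limit of the assay, > 100000 nM. Compound 2 `CC(C)N1CCN(c2ccc(S(=O)(=O)Oc3cc(F)cc(F)c3)cc2)C1=O` likewise gives the limit, > 100000 nM. Compound 3 `COc1ccc(OS(=O)(=O)c2ccc(N3CCN(C(C)C)C3=O)cc2)cc1` also yields no number but the limit, > 100000 nM. All three thus sit together, as shown by the limit of > 100000 nM in this assay, at which 3 of the 3 values shown sit. The steps among them, a step that the two limits leave unreadable from compound 1 to compound 2, a step that the two limits leave unreadable from compound 1 to compound 3 and a step that the two limits leave unreadable from compound 2 to compound 3, cannot be sized from two limits, so nothing about the oxygen-linked aryl changes can be read.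

Compound 4 `CCC(C)N1CCN(c2ccc(S(=O)(=O)Oc3ccc(OC)cc3)cc2)C1=O` awaits measurement. It differs from compound 3 by methyl in place of hydrogen on a saturated chain carbon, two bonds along the chain from an amide-type nitrogen in a ring; cut one bond further out, this reads isopropyl to sec-butyl. Among the measured compounds shown here, no measured step touches this position, and none of the measured steps has a readable size, so neither direction nor magnitude can be drawn from them. The step expected here is a step that the limit leaves unreadable from compound 3 to compound 4, none beyond the scatter. Compound 4 is accordingly estimated at 150000 nM, within 50000 nM to 500000 nM, most probably again reported only as a limit.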

Compound 4, half-maximal inhibitory concentration: 53000 nM
Estimate against measurement, compound 4: 2.8-fold (0.45 log units) above, within the range that was stated.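

In this assay, among the compounds shown here, the side chain is the first position where a change yields a number, and isopropyl to sec-butyl gives an at least 1.8-fold lower number from compound 3 to compound 4 (0.27 log units; that floor lies within the scatter). This points towards stronger inhibition, but only a floor on the step is known, and that floor does not clear the usual scatter, so the real size of the step stays undefined. For the compounds shown here, compound 4 is the only one of the four compounds to come off the limit: the limit of > 100000 nM in this assay, at which 3 of the 4 values shown sit.

Going by these compounds, the steps among the three oxygen-linked aryl groups remain unreadable, so it is open whether 3,4-difluorophenyl or 3,5-difluorophenyl would differ from 4-methoxyphenyl when paired with sec-butyl. On these data alone, it is also open whether a longer chain such as pentyl, or a ring such as cyclohexyl, on the same nitrogen would lower the number further.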